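Aryl for Benzyl on the Core Nitrogen

The compounds below may be only part of what the source reports. "The series", "measured", "known", "first", "only" and "open" are said of these compounds alone.

Measured in a functional assay on HCT-116 cells (Homo sapiens) for antiproliferative activity, read by CCK-8 assay, with a stated time of 72 h, tested at 2 uM; a lower number here means a weaker effect, a higher number a stronger effect of the compound at the concentration tested:
- compound 1 `CC(C)n1cnc2c(Nc3ccccc3)nc(NCOCc3ccc(C(=O)Nc4ccccc4N)cc3)nc21` gives 6.85%
- compound 2 `CC(C)n1cnc2c(Nc3ccccc3)nc(NCOCc3ccc(/C=C/C(=O)Nc4ccccc4N)cc3)nc21` gives 2.53%
- compound 3 `Nc1ccccc1NC(=O)c1ccc(Cn2cnc3c(NCc4ccccc4)nc(Cl)nc32)cc1` gives 68.3%

Compound 3 stands highest of the three; its nearest neighbour on the numbers is compound 1, which lies beyond the scatter below it, and compound 2 lies furthest below. Within the data shown here, the one step between compounds that differ in a single place is a number 4.3 percentage points lower from compound 1 to compound 2 (within the scatter), and it concerns a different part of the molecule from the change considered here.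

Compound 4 `Nc1ccccc1NC(=O)c1ccc(Cn2cnc3c(Nc4cccc(OC(F)(F)F)c4)nc(Cl)nc32)cc1` differs from compound 3 in one place: 3-(trifluoromethoxy)phenyl in place of benzyl on a nitrogen on an aromatic ring

Among the measured compounds shown here, no measured pair turns on this change, so the step from compound 3 to compound 4 has no direct precedent. Compound 1 carries an amine of the aryl kind on the same nitrogen, but it also differs from compound 3 in several other places, so the gap between compound 1 and compound 3 cannot be read as the effect of the aryl group alone. Compound 4 is therefore expected to stay in the region of compound 3, with wide uncertainty, at an estimated 55% (range 25% to 85%). The estimated step is a number 13.3 percentage points lower from compound 3 to compound 4 (beyond the scatter), which is expected to fall close to the scatter.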

Compound 4, a percentage reported as inhibition, at one concentration (the size of the read-out at that concentration, not a potency): 1.6%
Estimate against measurement, compound 4: 53.4 percentage points above; the whole stated range lies above it.
By their numbers in this assay, from the lowest: compounds 4, 2 and 1 (each within the scatter of the next); then compound 3.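

Among these compounds, the step from benzyl to 3-(trifluoromethoxy)phenyl gives the first measured reading of a change on this nitrogen, and in this assay it is a number 66.7 percentage points lower from compound 3 to compound 4 (beyond the scatter). Among the compounds shown here, the earlier compounds could not show this, since the only single-place step among them lay elsewhere in the molecule and stayed within the scatter, whereas here one exchange on a nitrogen on an aromatic ring, with the rest of the structure unchanged, removes nearly all of the effect seen at the tested concentration. The high number of compound 3 is therefore sensitive to the group on this nitrogen, although nothing available bears on what lies behind the drop.

The change does two things at once, setting the ring directly on the nitrogen and adding a trifluoromethoxy group, and the compounds shown do not separate these two parts of the exchange. A plain phenyl or a 3-(trifluoromethoxy)benzyl on the same nitrogen would tell them apart, and the read-out at a single concentration leaves open how far potency itself moves across this step.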